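Three Compounds at the Assay Limit and a Fourth

This account rests on a few compounds, and the source may have more. Where it says the series, first, only, none or still open, it means among the compounds named here.

Compound 3 `CN(Cc1cccc(F)c1)C(=O)CN(C)C(=O)c1ccc(S(C)(=O)=O)c([N+](=O)[O-])c1` has been tested in an assay on isolated protein for inhibition of thyroid hormone receptor alpha (Homo sapiens), read by fluorescence polarization (a higher number here means a weaker inhibitor, a lower number a stronger inhibitor), where compound 3 gives > 60000 nM, a limit of the assay rather than a number. The same holds for its two relatives: compound 1 `CN(Cc1ccccc1)C(=O)C1CCN(C(=O)c2ccc(S(C)(=O)=O)c([N+](=O)[O-])c2)CC1` gives > 60000 nM in this assay, which is a limit. Compound 2 `CCCN(C(=O)CN(C)C(=O)c1ccc(S(C)(=O)=O)c([N+](=O)[O-])c1)c1ccccc1` gives > 60000 nM in this assay, also a limit. So the limit of > 60000 nM in this assay, at which 3 of the 3 values shown sit, is where everything so far stands, and the only single-place change among them, a step that the two limits leave unreadable from compound 2 to compound 3, cannot be read because both ends are limits. Compound 4 `CC1CCN(C(=O)CN(C)C(=O)c2ccc(S(C)(=O)=O)c([N+](=O)[O-])c2)CC1` differs from compound 3 by 4-methylpiperidin-1-yl in place of (3-fluorobenzyl)(methyl)amino on a carbonyl carbon. Within the data shown here, no measured step bears on this change with a readable size, so the only guide is that every relative of compound 4 sits at the limit. The step from compound 3 to compound 4 is therefore expected to be a step that the limit leaves unreadable from compound 3 to compound 4, meaning no shift that could be read, and compound 4 is estimated at 120000 nM, within 40000 nM to 400000 nM, with a limit again the most likely outcome.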

Compound 4, half-maximal inhibitory concentration: > 60000 nM
Compound 4 was reported as a limit; the forecaster's own chance of this, stated with the estimate: 85%; the middle value is on the limit's open side.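

Compound 4 gives > 60000 nM, which is a limit of the assay and not a number. The steps to compound 4 from compound 2 and compound 3 therefore cannot be read. The compounds shown leave open which change to the shared core, if any, would give a readable value in this assay for this series.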